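The source may hold more compounds than are shown below. What is called first, only, known or untested is meant among the compounds shown, and "the series" means these compounds.

Measured in a functional assay on OST cells (Homo sapiens) for inhibition; a lower number here means a stronger inhibitor, a higher number a weaker inhibitor:
- compound 1 `O=c1[nH]c(=O)n([C@H]2C[C@H](O)[C@@H](CO)O2)cc1C#CI` gives 34000 nM
- compound 2 `C[Si](C)(C)C#Cc1cn([C@H]2C[C@H](O)[C@@H](CO)O2)c(=O)[nH]c1=O` gives 23000 nM
- compound 3 `C#Cc1cn([C@@H]2O[C@H](CO)[C@@H](O)[C@@H]2O)c(=O)[nH]c1=O` gives >= 250000 nM, which is a limit of this assay and not a number

Compound 3 therefore stands at the weak end of the measured set: in this assay only a limit is known for compound 3, and it is the only one of the three at the limit of >= 250000 nM in this assay, at which 1 of the 3 values shown sits. Compound 1 and compound 2 are within the scatter of each other.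

Compound 4 `C[Si](C)(C)C#Cc1cn([C@@H]2O[C@H](CO)[C@@H](O)[C@@H]2O)c(=O)[nH]c1=O` differs from compound 3 by a group of 4 heavy atoms (3 carbon, 1 silicon; no ring) in place of a hydrogen atom, on a triple-bonded carbon.

Among the compounds with values here, the one measured step that bears on this change is the exchange at the same position on the core of compound 1, a 1.5-fold lower number from compound 1 to compound 2 (0.17 log units; within the scatter). That step swaps an iodine atom rather than a hydrogen atom, and it lies within the scatter, so it gives no reason to expect a shift beyond the scatter from compound 3 to compound 4. Because compound 3 gives only >= 250000 nM, the starting point itself is not pinned to a number.

Compound 4 is expected to stay near the limit, with an estimated step of an at least 1.2-fold lower number from compound 3 to compound 4 (0.09 log units; that floor lies within the scatter). For compound 4 the estimate in this assay is 200000 nM, with a range of 50000 nM to 600000 nM, and a substantial chance that only a limit is reported.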

Compound 4, half-maximal inhibitory concentration: >= 176000 nM
Compound 4: no number, only a limit (the forecaster's own chance of this, stated with the estimate: 55%); the middle value is on the limit's open side.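

In this assay compound 4 gives only a limit, >= 176000 nM. Within the data shown here, with the group of 4 heavy atoms (3 carbon, 1 silicon; no ring) kept on the triple-bonded carbon, hydroxy in place of hydrogen on a saturated ring carbon gives an at least 7.6-fold higher number from compound 2 to compound 4 (0.88 log units; beyond the scatter), the first step that lies beyond the scatter, so the change on the saturated ring carbon registers in this read-out, whereas the exchange on the triple-bonded carbon from compound 1 to compound 2 stayed within the scatter. Compound 3 and compound 4 both end in limits, so the step between them cannot be read, and placing the silicon-bearing group in place of the hydrogen atom does not bring the hydroxy-bearing core to a measured number.

From the compounds shown here alone, it remains open whether any other group on the triple-bonded carbon of this hydroxy-bearing core, such as an amine, a carboxylic acid or a longer alkyl chain, would give a measurable value in this assay. Going by these compounds, the effect of a plain hydrogen atom on the triple-bonded carbon of the core of compound 1 also remains open.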